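The compounds below may be only part of what the source reports. "The series", "measured", "known", "first", "only" and "open" are said of these compounds alone.

Compound 1 `S=C1NCCCN1Cc1ccccc1` reads > 10000 nM in a functional assay on B16 cells (Mus musculus) for inhibition, with a stated time of 72 h (a higher number here means a weaker inhibitor, a lower number a stronger inhibitor), and that is a limit of the assay, not a number. Among the measured compounds shown here, compound 2 `Cc1ccc(CN2CCCNC2=S)cc1` carries one extra methyl on the aromatic ring and gives 5100 nM, the only true number so far in this assay. It therefore has no measured neighbour to be ranked against, only the limit of compound 1.

The next compound to be tested is compound 3 `S=C1NCCCN1Cc1ccc(Cl)cc1`. Its difference from compound 2 is small: chloro in place of methyl on an aromatic carbon. In words, this is chloro in place of methyl on an aromatic carbon.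

For the measured compounds named here, only one measured step bears on this change, and it sits at the same aromatic carbon: an at least 1.9-fold lower number from compound 1 to compound 2 (0.29 log units; that floor lies within the scatter). That step gives only a floor, and the floor lies within the scatter, so it offers no firm size to carry over. No step beyond the scatter is expected in this assay, and no direction can be favoured. The expected change is a 1.0-fold lower number from compound 2 to compound 3 (0.01 log units; within the scatter).

For compound 3 the estimate is 5000 nM, with an expected range of 2000 nM to 10000 nM.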

Compound 3, half-maximal inhibitory concentration: 2400 nM
For compound 3 the middle estimate is 2.1-fold (0.32 log units) above the measured one; low and high end bracket the measured number.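

Among the compounds shown here, at this position on the aromatic ring, the choice of group does move the reading in this assay: chloro in place of methyl gives a 2.1-fold lower number from compound 2 to compound 3 (0.33 log units; beyond the scatter) and this is the first step here with a true number at both ends. Chloro in place of hydrogen on the same carbon gives an at least 4.1-fold lower number from compound 1 to compound 3 (0.61 log units; beyond the scatter) and so clears the scatter, whereas the floor for methyl in place of hydrogen lay within it. The full size of that chloro step cannot be stated, because one end of it is a limit of the assay and not a number: the limit of > 10000 nM in this assay, at which 1 of the 3 values shown sits.

Going by these compounds, all of this rests on one ring position and two groups, so it remains open whether the change is particular to chloro or would also appear with fluoro or bromo. Also open, on these data alone, are how a methoxy group, an amine or a carboxylic acid would read at this carbon, and whether chloro would give a similar step on another carbon of the ring.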